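The compounds below may be only part of what the source reports. "The series", "measured", "known", "first", "only" and "open" are said of these compounds alone.

In a functional assay on L6 cells (Rattus norvegicus) for inhibition (a lower number here means a stronger inhibitor, a higher number a weaker inhibitor), the three measured compounds stand as follows:

Compound 1, `CC(C)c1c(C(=O)N(C)Cc2ccccc2)nn(-c2ccc(F)cc2)c1OC[C@@H](O)C[C@@H](O)CC(=O)O`, gives 6720 nM.
Compound 2, `CC(C)c1c(C(=O)NCc2cccc(F)c2F)nn(-c2ccc(F)cc2)c1OC[C@@H](O)C[C@@H](O)CC(=O)O`, gives 120 nM.
Compound 3, `CC(C)c1c(C(=O)N2CCCC2c2ccccc2)nn(-c2ccc(F)cc2)c1OC[C@@H](O)C[C@@H](O)CC(=O)O`, gives 4340 nM.

Compound 3 therefore sits near the weak end of this small set: the step of a 1.5-fold lower number from compound 1 to compound 3 (0.19 log units; within the scatter) is within the scatter, while the step of a 36-fold higher number from compound 2 to compound 3 (1.56 log units; beyond the scatter) is large. Compound 4, `CC(C)c1c(C(=O)N(C)Cc2cccc(F)c2)nn(-c2ccc(F)cc2)c1OC[C@@H](O)C[C@@H](O)CC(=O)O`, has not yet been measured. It differs from compound 3 in one place: (3-fluorobenzyl)(methyl)amino in place of 2-phenylpyrrolidin-1-yl on a carbonyl carbon. Among the measured compounds shown here, two measured steps bear on this. The step of a 56-fold lower number from compound 1 to compound 2 (1.75 log units; beyond the scatter) shows that a fluorinated benzyl amide can be a much stronger inhibitor, but there the amide also lost its methyl, and compound 4 keeps that methyl, as compound 1 does. The step of a 36-fold higher number from compound 2 to compound 3 (1.56 log units; beyond the scatter) shows how far the weak end lies from compound 2. Compound 4 is expected to land between those poles, with an estimated step of a 1.7-fold lower number from compound 3 to compound 4 (0.24 log units; within the scatter) in this assay toward a lower number. Compound 4 is estimated at 2500 nM, in a range from 600 nM to 9000 nM.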

Compound 4, half-maximal inhibitory concentration: 2470 nM
Compound 4: middle estimate off by 1.0-fold (0.01 log units), on the high side; low and high end bracket the measured number.
By their numbers in this assay, from the lowest: compound 2; then compounds 4, 3 and 1 (each within the scatter of the next, the first and the last beyond it).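

On the shared core, a fluoro in place of hydrogen on an aromatic carbon gives on its own a 2.7-fold lower number from compound 1 to compound 4 (0.43 log units; beyond the scatter) in this assay, so this single fluorine has a modest effect at most. The gap to the secondary amide stays large, at a 21-fold higher number from compound 2 to compound 4 (1.31 log units; beyond the scatter), so this fluorine accounts for only a small part of the strength of compound 2. The open-chain (3-fluorobenzyl)(methyl)amino group and the ring-containing 2-phenylpyrrolidin-1-yl group cannot be told apart here, with a 1.8-fold lower number from compound 3 to compound 4 (0.24 log units; within the scatter).

No measured information explains any of these steps. From the compounds shown here alone, it remains open how much of the remaining gap comes from the amide hydrogen and how much from the second fluorine, a question that a (3-fluorobenzyl)amino amide, with the methyl gone and one fluorine kept, would help to separate.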